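From hydroxy to methoxy on compound 3

A few compounds are considered here, and "the series" means these few. Any claim that something is new, unique, unknown or untested is made for them only; others in the source may bear on it.

In a physicochemical assay, read by spectrophotometry, with a stated time of 15 min (on this read-out higher numbers stand for weaker inhibition and lower numbers for stronger inhibition), compound 1 (`COc1cc(/C=N/NC(=O)CCc2nc3ccccc3c(=O)[nH]2)ccc1O`) reads 290000000 nM and compound 2 (`COc1cc(/C=N/NC(=O)CCc2nc3ccccc3c(=O)[nH]2)cc(OC)c1O`) reads 275000000 nM, a pair that the scatter does not separate. Compound 3 (`O=C(CCc1nc2ccccc2c(=O)[nH]1)N/N=C/c1cc(O)c(O)c(O)c1`) holds the lowest of the three numbers at 45000000 nM and so shows the strongest inhibition of this small set.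

Compound 4 (`COc1cc(/C=N/NC(=O)CCc2nc3ccccc3c(=O)[nH]2)cc(O)c1O`) differs from compound 3 by a single change (methyl in place of hydrogen on an oxygen on an aromatic ring), hydroxy to methoxy. Among the compounds with values here, no measured pair isolates exactly this change. Within the data shown here, two steps bear on it. Adding a methoxy on an aromatic carbon gave a 1.1-fold lower number from compound 1 to compound 2 (0.02 log units; within the scatter) and offers little guidance. The closer guide is the modest exchange of 4-hydroxy-3-methoxyphenyl for 3,4,5-trihydroxyphenyl, which gave a 6.4-fold lower number from compound 1 to compound 3 (0.81 log units; beyond the scatter). Compound 4 carries a methoxy as compound 1 does, so part of that step is expected to be lost.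

The expected step is a 2.6-fold higher number from compound 3 to compound 4 (0.41 log units; beyond the scatter), toward a higher number and weaker inhibition. Compound 4 is estimated at 115000000 nM, with an expected range from 55000000 nM to 270000000 nM.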

Compound 4, half-maximal inhibitory concentration: 50000000 nM
For compound 4 the middle estimate is 2.3-fold (0.36 log units) above the measured one; the measured number lies below the stated range.
By their numbers in this assay, from the lowest: compounds 3 and 4 (each within the scatter of the next); then compounds 2 and 1 (each within the scatter of the next).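

In this assay, methyl in place of hydrogen on an oxygen on an aromatic ring is a step that the scatter does not resolve (a 1.1-fold higher number from compound 3 to compound 4 (0.05 log units; within the scatter)), so on this ring a methoxy does not by itself bring the higher numbers of compounds 1 and 2. The change that matters is the free hydroxy: hydrogen in place of methyl on the oxygen gives a 5.5-fold lower number from compound 2 to compound 4 (0.74 log units; beyond the scatter), and adding a hydroxy to the aromatic ring gives a 5.8-fold lower number from compound 1 to compound 4 (0.76 log units; beyond the scatter), both beyond the scatter. Nothing available explains why this hydroxy counts and the methyl on the neighbouring oxygen does not.

As far as these compounds go, whether a longer ether such as ethoxy would read like methoxy here remains open. So does the effect of an amine or a fluorine in place of this hydroxy.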